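Working notes: hydrocarbon substituent changes at the ring-oxygen position

The compounds below may be only part of what the source reports. "The series", "measured", "known", "first", "only" and "open" are said of these compounds alone.

Compound 1 `COc1ccc(Nc2cc(C3CCCCC3)oc(=O)c2)cc1` gives 8.61 uM in a functional assay on DU-145 cells (Homo sapiens) for cytotoxicity, read by MTT assay, with a stated time of 72 h; a higher number here means that more compound is needed for the effect, a lower number that less compound is needed. Compound 2 `CCCCCc1cc(Nc2ccc(OC)cc2)cc(=O)o1` gives 5.94 uM in this assay.

Among the compounds with values here, on the two numbers so far compound 2 holds the lowest; its nearest neighbour is compound 1, and the step of a 1.4-fold lower number from compound 1 to compound 2 (0.16 log units; within the scatter) lies within the scatter. Compound 3 `COc1ccc(Nc2cc(/C=C/c3ccccc3)oc(=O)c2)cc1` is the next candidate; it carries 2-phenylethenyl in place of pentyl on an aromatic carbon.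

Within the data shown here, the only measured step bearing on this change is a 1.4-fold lower number from compound 1 to compound 2 (0.16 log units; within the scatter), which also swapped one hydrocarbon group for another at the same place and produced nothing beyond the scatter. The new group brings an aromatic ring and a double bond, for which no measured comparison exists. The expectation is therefore a step of about a 1.1-fold lower number from compound 2 to compound 3 (0.03 log units; within the scatter), that is, no change beyond the scatter. For compound 3 the estimated value is 5.5 uM, with a range from 1.5 uM to 18 uM.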

Compound 3, concentration for half-maximal effect: 0.11 uM
For compound 3 the middle estimate is 50-fold (1.70 log units) above the measured one; the measured number lies below the stated range.
By their numbers in this assay, from the lowest: compound 3; then compounds 2 and 1 (each within the scatter of the next).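

In this assay this position, next to the ring oxygen, proves far more responsive to the choice of hydrocarbon group than the earlier pair suggested: 2-phenylethenyl in place of pentyl gives (a 54-fold lower number from compound 2 to compound 3 (1.73 log units; beyond the scatter)), and 2-phenylethenyl in place of cyclohexyl gives (a 78-fold lower number from compound 1 to compound 3 (1.89 log units; beyond the scatter)). Exchanging cyclohexyl for pentyl stayed within the scatter, so neither a ring as such nor an open chain as such sets the level here; of the three groups, only 2-phenylethenyl, with its aromatic ring and its double bond, stands apart. No evidence at hand accounts for this step.

The compounds shown do not separate the aromatic ring from the double bond; a 2-phenylethyl group and a propenyl group would address that. On these data alone, how an amine or a hydroxyl on the new phenyl ring would act also remains open.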